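This account rests on a few compounds, and the source may have more. Where it says the series, first, only, none or still open, it means among the compounds named here.

Measured so far:
Compound 1 `Cc1nnc(SCc2cc(=O)c3cc(Cl)ccc3o2)o1`: in a functional assay on SW480 cells (Homo sapiens) for cytotoxicity, read by MTT assay, with a stated time of 72 h (on this read-out higher numbers stand for weaker inhibition and lower numbers for stronger inhibition), compound 1 gives > 25000 nM, which is a limit of the assay and not a number.
Compound 2 `Cc1cc(C)n2nc(SCc3cc(=O)c4cc(Cl)ccc4o3)nc2n1`: compound 2 gives > 25000 nM, again a limit.
Compound 3 `Cc1nnc(SCc2cc(=O)c3ccccc3o2)o1`: compound 3 gives > 25000 nM, again a limit.

Compound 1 thus stands at the limit, as do the two other values shown, which is summed up in the limit of > 25000 nM in this assay, at which 3 of the 3 values shown sit. The step that the two limits leave unreadable from compound 1 to compound 3 is unreadable since both ends are limits.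

Compound 4 `Cc1nnc(SCc2cc(=O)c3cc(Cl)ccc3o2)s1` differs from compound 1 by 5-methyl-1,3,4-thiadiazol-2-yl in place of 5-methyl-1,3,4-oxadiazol-2-yl on a sulfur. For the measured compounds named here, no measured step touches this change, and every value in this assay sits at the limit, so nothing points to a shift in either direction. In this assay the change from compound 1 to compound 4 is expected to give no step beyond the scatter, most probably a further limit. For compound 4 the estimate is 35000 nM, with a range from 10000 nM to 120000 nM. The step expected is a step that the limit leaves unreadable from compound 1 to compound 4.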

Compound 4, half-maximal inhibitory concentration: > 25000 nM
Compound 4: only a limit was reported (the forecaster's own chance of this, stated with the estimate: 80%); the middle value does not contradict the limit.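

In this assay compound 4 gives > 25000 nM, a limit and not a number, so the change from compound 1 to compound 4 gives no readable step. The compounds shown leave open whether any change on the shared core gives a readable value: the limit of > 25000 nM in this assay, at which 4 of the 4 values shown sit.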